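The compounds below may be only part of what the source reports. "The series", "measured", "known", "first", "only" and "open" are said of these compounds alone.

Measured so far:
compound 1 `C=C1C(=O)O[C@@H]2CC(C)=C([C@@H](C)CCCOC(C)=O)[C@@H](OC(=O)CN3CCCC3)[C@H]12`: 20500 nM
compound 2 `C=C1C(=O)O[C@@H]2CC(C)=C([C@@H](C)CCCOC(C)=O)[C@@H](OC(=O)COc3ccc(C(C)=O)cc3)[C@H]12`: 40100 nM
compound 3 `C=C1C(=O)O[C@@H]2CC(C)=C([C@@H](C)CCCOC(C)=O)[C@@H](OC(=O)COc3ccc([N+](=O)[O-])cc3[N+](=O)[O-])[C@H]12`: > 100000 nM

All three numbers come from a functional assay on HCT-116 cells (Homo sapiens) for cytotoxicity, read by sulforhodamine B assay, with a stated time of 72 h; on this read-out higher numbers stand for weaker inhibition and lower numbers for stronger inhibition. For compound 3 the reading > 100000 nM is a limit of the assay and not a number, so compound 3 sits at the limit of > 100000 nM in this assay, at which 1 of the 3 values shown sits, the highest reading of the set.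

Compound 4 `C=C1C(=O)O[C@@H]2CC(C)=C([C@@H](C)CCCOC(C)=O)[C@@H](OC(=O)COc3cccc4cccnc34)[C@H]12` differs from compound 3 by quinolin-8-yl in place of 2,4-dinitrophenyl on an oxygen on a saturated carbon. Two measured steps change the same position: a 2.0-fold higher number from compound 1 to compound 2 (0.29 log units; within the scatter) and an at least 2.4-fold higher number from compound 2 to compound 3 (0.39 log units; beyond the scatter). Moving from the 2,4-dinitrophenyl back to a single aromatic system with one nitrogen is expected to return the number to the range of compound 1 and compound 2 in this assay. Compound 4 is therefore estimated at 45000 nM, between 15000 nM and 140000 nM, which would be an at least 2.2-fold lower number from compound 3 to compound 4 (0.34 log units; beyond the scatter).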

Compound 4, half-maximal inhibitory concentration: 12100 nM
Compound 4: middle estimate off by 3.7-fold (0.57 log units), on the high side; measured number below the stated range.
By their numbers in this assay, from the lowest: compounds 4, 1 and 2 (each within the scatter of the next, the first and the last beyond it). At a limit, above all of these: compound 3.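

Quinolin-8-yl on this oxygen reverses the loss seen with 2,4-dinitrophenyl, giving an at least 8.2-fold lower number from compound 3 to compound 4 (0.91 log units; beyond the scatter), though that step starts from a limit and not a number: the limit of > 100000 nM in this assay, at which 1 of the 4 values shown sits.

It also improves on 4-acetylphenyl, with a 3.3-fold lower number from compound 2 to compound 4 (0.52 log units; beyond the scatter), so the aromatic group here can move the number in either direction. Against the pyrrolidin-1-yl compound the result is a 1.7-fold lower number from compound 1 to compound 4 (0.23 log units; within the scatter), so those two cannot be ranked.

From the compounds shown here alone, whether the ring nitrogen of quinolin-8-yl matters remains open. A naphthalen-1-yl group on this oxygen would test that, and an unsubstituted phenyl would give a baseline for the substituted rings.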